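The source may report more compounds than this note shows. Statements on the series, on what has been measured and on what is new or still open speak of the compounds shown alone.

The measured compounds:
compound 1, `CCCC/N=C(\S)OC[C@H]1OC(n2cnc3c(NC4CCOC4)ncnc32)[C@H](O)[C@@H]1O`, gives 157 nM in an assay on DDT1 cells (Cricetulus griseus) for binding affinity to adenosine receptor A1 (Homo sapiens), read by radioligand binding; on this read-out lower numbers stand for stronger inhibition and higher numbers for weaker inhibition.
compound 2, `CC(C)/N=C(\S)OC[C@H]1OC(n2cnc3c(NC4CCOC4)ncnc32)[C@H](O)[C@@H]1O`, gives 36 nM in this assay.
compound 3, `O=C(NC1CCC1)OC[C@H]1OC(n2cnc3c(NC4CCOC4)ncnc32)[C@H](O)[C@@H]1O`, gives 306 nM in this assay.

All three share one core and differ only in the group carried on the oxygen of the saturated carbon. Compound 3 has the highest number of the three; its nearest neighbour is compound 1, and these two lie within the scatter of each other, while the gap to compound 2 is wider: an 8.5-fold higher number from compound 2 to compound 3 (0.93 log units; beyond the scatter). Compound 4, `O=C(NCc1ccccc1)OC[C@H]1OC(n2cnc3c(NC4CCOC4)ncnc32)[C@H](O)[C@@H]1O`, is not yet measured. It differs from compound 3 in one place: benzyl in place of cyclobutyl on an amide-type nitrogen. For the measured compounds named here, no measured step swaps exactly this group, so the expectation rests on how much this end of the molecule has moved the numbers so far: a 4.4-fold lower number from compound 1 to compound 2 (0.64 log units; beyond the scatter) and a 1.9-fold higher number from compound 1 to compound 3 (0.29 log units; within the scatter). Both are modest, so a modest shift is expected here too. In the step of a 4.4-fold lower number from compound 1 to compound 2 (0.64 log units; beyond the scatter) the smaller group gave the lower number, so the larger benzyl is expected to move the number up rather than down. Compound 4 is therefore estimated at 450 nM, with a range from 130 nM to 1500 nM, which means an expected step of a 1.5-fold higher number from compound 3 to compound 4 (0.17 log units; within the scatter).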

Compound 4, inhibition constant: 1830 nM
The estimate for compound 4 lay 4.1-fold (0.61 log units) below the measured number, and the stated range ends below it.
By their numbers in this assay, from the lowest: compound 2; then compounds 1 and 3 (each within the scatter of the next); then compound 4.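

In this assay, the step of a 6.0-fold higher number from compound 3 to compound 4 (0.78 log units; beyond the scatter) is the first one shown that changes only the group on the amide-type nitrogen, and it lies beyond the scatter, so this nitrogen's substituent matters even when the rest of the carbamoyl group stays the same. Compound 4 also extends the span of numbers at this end of the molecule: the steps of a 12-fold higher number from compound 1 to compound 4 (1.07 log units; beyond the scatter) and a 51-fold higher number from compound 2 to compound 4 (1.71 log units; beyond the scatter) are both large, and they place compound 4 at the high end of the series, clear of all three earlier compounds. Nothing given here explains why benzyl gives the higher number.

With only cyclobutyl and benzyl on this nitrogen, the compounds shown cannot separate the effect of the aromatic ring from that of the group's size, and a cyclohexyl or a phenyl there would help to pull the two apart. On these data alone, it also remains open how the two kinds of linker compare with one group held constant, as a carbamoyl carrying isopropyl would allow against compound 2.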